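The source may report more compounds than this note shows. Statements on the series, on what has been measured and on what is new or still open speak of the compounds shown alone.

Of the compounds shown here, three sharing one core have been measured in a functional assay, with a stated time of 30 min; on this read-out lower numbers stand for stronger inhibition and higher numbers for weaker inhibition. Compound 1 `CCCCc1oc2ccc(/N=C/c3ccc(F)cc3)cc2c1C(=O)c1ccc(OC)cc1` carries a 4-fluorophenyl on the carbon double-bonded to nitrogen, and in this assay compound 1 gives 100 ug/mL. Compound 2 `CCCCc1oc2ccc(/N=C/c3ccc(OC)cc3OC)cc2c1C(=O)c1ccc(OC)cc1` carries a 2,4-dimethoxyphenyl there and gives 20.5 ug/mL. Compound 3 `CCCCc1oc2ccc(/N=C/c3ccc(O)cc3O)cc2c1C(=O)c1ccc(OC)cc1` carries a 2,4-dihydroxyphenyl and gives 7.55 ug/mL, the lowest of the three numbers. The steps were a 4.9-fold lower number from compound 1 to compound 2 (0.69 log units; beyond the scatter), a 13-fold lower number from compound 1 to compound 3 (1.12 log units; beyond the scatter) and a 2.7-fold lower number from compound 2 to compound 3 (0.43 log units; beyond the scatter).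

Compound 4 `CCCCc1oc2ccc(/N=C/c3ccc(OCC)c(OC)c3)cc2c1C(=O)c1ccc(OC)cc1` is not yet measured. It differs from compound 3 in one place: 4-ethoxy-3-methoxyphenyl in place of 2,4-dihydroxyphenyl on a carbon with a double bond to nitrogen. The closest guide is the step from compound 2 to compound 3, where swapping two methoxy groups for two hydroxy groups gave a 2.7-fold lower number from compound 2 to compound 3 (0.43 log units; beyond the scatter). Compound 4, like compound 2, has alkoxy groups and no hydrogen-bond donors on that ring, so the reverse of that step is the expectation: a modest rise in the number from compound 3, estimated as a 3.3-fold higher number from compound 3 to compound 4 (0.52 log units; beyond the scatter). The different positions of the two alkoxy groups and the longer ethoxy chain are not covered by any measured pair, so the range is kept wide. For compound 4 the expected value in this assay is 25 ug/mL, with a range from 10 ug/mL to 60 ug/mL.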

Compound 4, half-maximal inhibitory concentration: 14.8 ug/mL
Compound 4: the middle estimate sits 1.7-fold (0.23 log units) above what was measured; the range from low to high includes it.
By their numbers in this assay, from the lowest: compounds 3, 4 and 2 (each within the scatter of the next, the first and the last beyond it); then compound 1.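

In this assay, the 4-ethoxy-3-methoxyphenyl of compound 4, with 0 hydrogen-bond donors and 11 heavy atoms, cannot be told apart from either the 2,4-dihydroxyphenyl of compound 3 (a 2.0-fold higher number from compound 3 to compound 4 (0.29 log units; within the scatter)) or the 2,4-dimethoxyphenyl of compound 2 (a 1.4-fold lower number from compound 2 to compound 4 (0.14 log units; within the scatter)), so hydrogen-bond donors on this group are not needed for a number in this range, and the larger group is tolerated on the carbon with a double bond to nitrogen. The 4-fluorophenyl of compound 1 stays clearly apart (a 6.8-fold lower number from compound 1 to compound 4 (0.83 log units; beyond the scatter)), which makes all three groups carrying two oxygen atoms give lower numbers than it, with no compound shown going against this. Nothing shown explains why these groups differ from 4-fluorophenyl.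

Still open, on these data alone, is whether one oxygen group on the phenyl, such as a lone hydroxy or a lone methoxy, would be enough to separate a compound from compound 1. Also open, as far as these compounds go, is how an amine, a carboxylic acid or a longer chain such as butoxy would behave on this ring.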